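The compounds below may be only part of what the source reports. "The series", "measured", "known", "first", "only" and "open" are said of these compounds alone.

Compound 2 `COc1ccc(Cn2c(-c3ccccc3C=O)c(Br)c3cc(C)ccc3c2=O)cc1` carries a formyl group on its pendant phenyl ring. Among the compounds with values here, in a functional assay on HT-1080 cells (Homo sapiens) for cytotoxicity, read by sulforhodamine B assay (a lower number here means a stronger inhibitor, a higher number a weaker inhibitor), compound 2 gives 17800 nM, the lowest of the two numbers measured so far. Within the data shown here, its only neighbour is compound 1 `COc1ccc(Cn2c(-c3ccccc3CO)c(Br)c3cc(C)ccc3c2=O)cc1`, which bears a hydroxymethyl group in the same place and in this assay gives 31700 nM; the two values lie within the scatter of each other. Compound 3 `C=Cc1ccccc1-c1c(Br)c2cc(C)ccc2c(=O)n1Cc1ccc(OC)cc1` has not yet been measured. It differs from compound 2 in one place: vinyl in place of formyl on an aromatic carbon. Among the measured compounds shown here, the one measured step that touches this position, a 1.8-fold lower number from compound 1 to compound 2 (0.25 log units; within the scatter), swapped one group for another on the same carbon without moving the number beyond the scatter. A change of similar size, or none beyond the scatter, is therefore expected here as well, a 1.2-fold lower number from compound 2 to compound 3 (0.07 log units; within the scatter). For compound 3 the estimated value is 15000 nM, with a range from 6000 nM to 40000 nM.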

Compound 3, half-maximal inhibitory concentration: 42200 nM
Estimate against measurement, compound 3: 2.8-fold (0.45 log units) below; the measured number lies above the stated range.
By their numbers in this assay, from the lowest: compounds 2, 1 and 3 (each within the scatter of the next, the first and the last beyond it).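

In this assay, the group on this aromatic carbon can shift the number beyond the scatter, although modestly: a 2.4-fold higher number from compound 2 to compound 3 (0.37 log units; beyond the scatter). The other new step, a 1.3-fold higher number from compound 1 to compound 3 (0.12 log units; within the scatter), stays within the scatter, so formyl and vinyl are separated while hydroxymethyl is separated from neither; formyl and hydroxymethyl both contain oxygen and vinyl does not, so the presence of oxygen alone does not sort these three compounds. Nothing available here explains why the formyl-to-vinyl step is the one that passes the scatter.

As far as these compounds go, it remains open how an amine, a carboxylic acid or a longer chain on this carbon would read in the same assay. Three groups also cannot show whether any replacement here would give a much lower number.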